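Trifluoromethylphenyl for dichlorophenyl on the amide-type nitrogen

A few compounds are considered here, and "the series" means these few. Any claim that something is new, unique, unknown or untested is made for them only; others in the source may bear on it.

Three compounds of the series have numbers in a functional assay on Hs-578T cells (Homo sapiens) for inhibition, read by sulforhodamine B assay, with a stated time of 48 h; a higher number here means a weaker inhibitor of growth, a lower number a stronger inhibitor of growth. Compound 1 `O=C(Nc1cccc(-n2cc(-c3ccncc3)c(-c3ccc(Cl)c(O)c3)n2)c1)Nc1ccc(Cl)c(Cl)c1` gives 785 nM, the lowest of the three. Compound 3 `COc1cc(-c2nn(-c3cccc(NC(=O)c4ccccc4)c3)cc2-c2ccncc2)ccc1Cl` gives 1110 nM, which sits within the scatter of compound 1. Compound 2 `COc1cc(-c2nn(-c3cccc(NC(=O)c4ccc(Cl)c(C(F)(F)F)c4)c3)cc2-c2ccncc2)ccc1Cl` gives 2170 nM, the furthest from compound 1 and beyond the scatter. Going by the values given here, the one step between measured neighbours is a 2.0-fold lower number from compound 2 to compound 3 (0.29 log units; within the scatter), a change on a carbonyl carbon.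

Compound 4 `O=C(Nc1cccc(-n2cc(-c3ccncc3)c(-c3ccc(Cl)c(O)c3)n2)c1)Nc1cccc(C(F)(F)F)c1` is the unmeasured partner of compound 1. The change is 3-(trifluoromethyl)phenyl in place of 3,4-dichlorophenyl on an amide-type nitrogen, on an amide-type nitrogen whose other neighbour is a carbonyl carbon. Among the compounds with values here, no measured step touches this nitrogen, so the step from compound 2 to compound 3 bears on it only loosely: there, swapping a halogenated aryl for a plain one moved the number within the scatter, which suggests that aryl substitution at this end of the molecule is not decisive. The expected step is therefore a 1.3-fold higher number from compound 1 to compound 4 (0.11 log units; within the scatter), none beyond the scatter. Compound 4 is estimated at 1000 nM, in the range 400 nM to 2600 nM.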

Compound 4, concentration for 50% growth inhibition: 3310 nM
Estimate against measurement, compound 4: 3.3-fold (0.52 log units) below; measured number outside the range, above it.
By their numbers in this assay, from the lowest: compounds 1, 3, 2 and 4 (each within the scatter of the next, the first and the last beyond it).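

In this assay, going by these compounds alone, the step at the amide-type nitrogen is the first measured at this place: a 4.2-fold higher number from compound 1 to compound 4 (0.62 log units; beyond the scatter). It shows that the aryl group on this nitrogen can move the number beyond the scatter, so 3,4-dichlorophenyl and 3-(trifluoromethyl)phenyl are not interchangeable here, whereas the aryl change on the carbonyl carbon, a 2.0-fold lower number from compound 2 to compound 3 (0.29 log units; within the scatter), stayed within the scatter. Nothing measured on these compounds accounts for the size of this step.

Still open, on these data alone, is how a 4-chlorophenyl or a 3-chlorophenyl on this nitrogen would read, which would show whether one chlorine alone matches the 3,4-dichlorophenyl of compound 1. Also open, as far as these compounds go, is whether a more distant group, such as a 4-(morpholin-4-yl)phenyl, would hold the number of compound 1 or lose it as compound 4 does.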